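The source may hold more compounds than are shown below. What is called first, only, known or untested is meant among the compounds shown, and "the series" means these compounds.

Compounds measured so far in an assay on CHO cells for displacement of a labelled ligand from 5-hydroxytryptamine receptor 1B (Homo sapiens); on this read-out lower numbers stand for stronger inhibition and higher numbers for weaker inhibition:

Compound 1, `CN(CC1CCN(CCCc2c[nH]c3ccc(-n4cnnc4)cc23)CC1)C(=O)Nc1ccccc1`: 6.2 nM
Compound 2, `C[C@@H](NCC1CCN(CCCc2c[nH]c3ccc(-n4cnnc4)cc23)CC1)c1ccccc1`: 14 nM
Compound 3, `CC(=O)Nc1ccc([C@H](C)NCC2CCN(CCCc3c[nH]c4ccc(-n5cnnc5)cc34)CC2)cc1`: 9.3 nM

All three share the same core and differ only in the group on the chain that hangs from the saturated ring. Compound 3 stands second of the three numbers, and its gaps to compound 1 and to compound 2 both lie within the scatter of this assay, so none of the three can be called stronger or weaker than the others with confidence. Two steps are known: a 2.3-fold higher number from compound 1 to compound 2 (0.35 log units; beyond the scatter) concerns a different part of the chain and does not bear directly on what follows, whereas a 1.5-fold lower number from compound 2 to compound 3 (0.18 log units; within the scatter) is the exact reverse of the change now considered.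

Compound 4, `C[C@H](NCC1CCN(CCCc2c[nH]c3ccc(-n4cnnc4)cc23)CC1)c1ccccc1`, differs from compound 3 by hydrogen in place of acetamido on an aromatic carbon. Since the same change in the other direction moved the number only within the scatter, the expected step of a 1.5-fold higher number from compound 3 to compound 4 (0.18 log units; within the scatter) is small, a slightly higher number at most, and not beyond the scatter. Compound 4 is therefore estimated at 14 nM, with a likely range from 5 nM to 45 nM.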

Compound 4, half-maximal inhibitory concentration: 58 nM
Beside the measured number, compound 4's estimate is 4.1-fold (0.62 log units) below it, and the stated range ends below it.
By their numbers in this assay, from the lowest: compounds 1, 3 and 2 (each within the scatter of the next, the first and the last beyond it); then compound 4.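

Among these compounds, at this place on the aromatic ring, the acetamido group matters more than the earlier compounds suggested: compound 3 and compound 4 are drawn with the same configuration, and replacing it with hydrogen gives a 6.2-fold higher number from compound 3 to compound 4 (0.79 log units; beyond the scatter). The configuration at the chain carbon matters too, with a 4.1-fold higher number from compound 2 to compound 4 (0.62 log units; beyond the scatter), and this step can be read cleanly for one reason: the fact that compounds 2 and 4 differ only in the configuration as drawn Configuration also shapes the comparison with the methyl(phenylcarbamoyl)amino group, since a 9.4-fold higher number from compound 1 to compound 4 (0.97 log units; beyond the scatter) is a wider gap than a 2.3-fold higher number from compound 1 to compound 2 (0.35 log units; beyond the scatter).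

The compounds shown leave open how acetamido behaves on the opposite configuration at the chain carbon, since that pairing cannot be compared here in one place only. As far as these compounds go, it also remains open whether a smaller group on this aromatic carbon, such as an amine or a hydroxyl, would keep the number near that of compound 3.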